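A few compounds are considered here, and "the series" means these few. Any claim that something is new, unique, unknown or untested is made for them only; others in the source may bear on it.

Compound 1 `CC1(C)[C@H]2CC[C@]1(C)N(Cc1cn(-c3ccccc3Br)nn1)C(=O)C2` has been tested in a functional assay on SGC-7901 cells (Homo sapiens) for inhibition, read by MTT assay, with a stated time of 24 h (a lower number here means a stronger inhibitor, a higher number a weaker inhibitor), where compound 1 gives 500 nM. Two companions share its core and differ from it only in the group carried on the aromatic nitrogen: compound 2 `CC1(C)[C@H]2CC[C@]1(C)N(Cc1cn(-c3ccc(C#N)cc3)nn1)C(=O)C2` gives 500 nM, and compound 3 `CC1(C)[C@H]2CC[C@]1(C)N(Cc1cn(-c3ccc(F)cc3)nn1)C(=O)C2` gives 500 nM. Compound 1 therefore stands level with both at the digits shown; the steps of no change at the digits printed from compound 1 to compound 2 (within the scatter) and no change at the digits printed from compound 1 to compound 3 (within the scatter) lie within the scatter, and so does no change at the digits printed from compound 2 to compound 3 (within the scatter). Compound 4 `CC1(C)[C@H]2CC[C@]1(C)N(Cc1cn(-c3cccc(Cl)c3)nn1)C(=O)C2` has not yet been measured. It differs from compound 1 by 3-chlorophenyl in place of 2-bromophenyl on an aromatic nitrogen. The two measured steps that bear on this change, each exchanging the group on the aromatic nitrogen for another, left the read-out unmoved, so this third exchange is expected to do the same, with no step beyond the scatter in this assay. On that basis compound 4 is estimated at 500 nM, between 250 nM and 1000 nM. The expected step is accordingly no change at the digits printed from compound 1 to compound 4 (within the scatter).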

Compound 4, half-maximal inhibitory concentration: 510 nM
The estimate for compound 4 lay 1.0-fold (0.01 log units) below the measured number; the measured number falls inside the stated range.
By their numbers in this assay, from the lowest: compounds 1, 2, 3 and 4 (each within the scatter of the next).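

Replacing the group on the aromatic nitrogen with 3-chlorophenyl gives a 1.0-fold higher number from compound 1 to compound 4 (0.01 log units; within the scatter) and a 1.0-fold higher number from compound 3 to compound 4 (0.01 log units; within the scatter) and a 1.0-fold higher number from compound 2 to compound 4 (0.01 log units; within the scatter) in this assay. The earlier compounds shown here covered only 2-bromophenyl, 4-cyanophenyl and 4-fluorophenyl; with 3-chlorophenyl added, all four substituted phenyl groups stand within the scatter of one another, so the read-out does not tell them apart at this position. No evidence is available to account for this flat result.

As far as these compounds go, all four compounds keep a six-membered aromatic ring of carbon on this nitrogen, so it remains open whether a phenyl bearing an amine or a carboxylic acid, a saturated cyclohexyl ring, or a longer alkyl chain would stay level with them. From the compounds shown here alone, the effect of changes to the shared core also remains open.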